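The source may report more compounds than this note shows. Statements on the series, on what has been measured and on what is new or still open speak of the compounds shown alone.

Measured in a functional assay on SK-OV-3 cells (Homo sapiens) for inhibition, read by CCK-8 assay, with a stated time of 70 h; on this read-out higher numbers stand for weaker inhibition and lower numbers for stronger inhibition:
- compound 1 `COc1ccc(COc2ccc(OCCOCCNC3CCCC3)cc2)cc1`: 15700 nM
- compound 2 `c1ccc(COc2ccc(COc3ccc(OCCOCCNC4CCCCC4)cc3)cc2)cc1`: 8080 nM
- compound 3 `COC(=O)c1ccc(COc2ccc(OCCOCCNC3CCCC3)cc2)cc1`: 6990 nM

Compound 3, at 6990 nM, lies within the scatter of compound 2, at 8080 nM. It stands clearly apart from compound 1, with a 2.2-fold lower number from compound 1 to compound 3 (0.35 log units; beyond the scatter).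

The next change leads to compound 4 `c1ccc(COc2ccc(COc3ccc(OCCOCCNC4CCCC4)cc3)cc2)cc1`: benzyloxy in place of methoxycarbonyl on an aromatic carbon. This places benzyloxy in place of methoxycarbonyl on an aromatic carbon, para to a large group.

Among the compounds with values here, only one measured step bears directly on this position: a 2.2-fold lower number from compound 1 to compound 3 (0.35 log units; beyond the scatter). It is modest, and it does not involve benzyloxy. Compound 4 differs elsewhere in the molecule from compound 2, which also carries benzyloxy. Compound 2 gives 8080 nM. That value is the closest available guide, though with three compounds it is thin support. From the compounds shown here alone, neither observation points to a large shift, so no change beyond the scatter is expected in this assay, and the direction remains open. The expected change is a 1.1-fold higher number from compound 3 to compound 4 (0.06 log units; within the scatter).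

For compound 4 the estimated value is 8000 nM, with an expected range of 4000 nM to 16000 nM.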

Compound 4, half-maximal inhibitory concentration: 10000 nM
Compound 4: the middle estimate sits 1.3-fold (0.10 log units) below what was measured, within the range that was stated.
By their numbers in this assay, from the lowest: compounds 3, 2, 4 and 1 (each within the scatter of the next, the first and the last beyond it).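

Working from this assay, the aromatic carbon para to a large group accepts benzyloxy in place of methoxycarbonyl without a shift beyond the scatter, with a 1.4-fold higher number from compound 3 to compound 4 (0.16 log units; within the scatter), even though benzyloxy brings a six-membered aromatic ring of carbon only that methoxycarbonyl lacks. The amine nitrogen now has its first direct comparison with the aromatic group held constant: cyclopentyl in place of cyclohexyl gives a 1.2-fold higher number from compound 2 to compound 4 (0.09 log units; within the scatter), also within the scatter. Phenyl in place of hydrogen on the saturated chain carbon bound to an oxygen on an aromatic ring gives a 1.6-fold lower number from compound 1 to compound 4 (0.20 log units; within the scatter), again within the scatter, so among the single changes read so far only a 2.2-fold lower number from compound 1 to compound 3 (0.35 log units; beyond the scatter) lies beyond it.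

No measurement on these compounds accounts for any of these steps. Still open, from the compounds shown here alone, is whether a carboxylic acid or a primary amide at the same aromatic carbon, or a piperidine or a longer alkyl chain on the amine nitrogen, would move the number beyond the scatter in this assay.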